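Methyl on the Six-Membered Ring of the Shared Core

This account rests on a few compounds, and the source may have more. Where it says the series, first, only, none or still open, it means among the compounds named here.

Measured so far:
compound 1, `CC(C)c1cc(Cn2ccc3cc(OCC(=O)O)ccc32)ccc1O`, 1.04 nM
compound 2, `Cc1cc2cc(OCC(=O)O)ccc2n1Cc1ccc(O)c(C(C)C)c1`, 1.12 nM

Both compounds were tested in an assay on HeLa cells for displacement of a labelled ligand from thyroid hormone receptor beta (Homo sapiens); on this read-out higher numbers stand for weaker inhibition and lower numbers for stronger inhibition. Compound 1 holds the lowest of the two numbers, but compound 2 lies within the scatter of it, so the two cannot be told apart. Going by the values given here, the only measured step, a 1.1-fold higher number from compound 1 to compound 2 (0.03 log units; within the scatter), was a methyl in place of hydrogen on an aromatic carbon, and it produced no change beyond the scatter.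

Compound 3, `Cc1cc(OCC(=O)O)cc2ccn(Cc3ccc(O)c(C(C)C)c3)c12`, has not yet been measured. It differs from compound 1 by methyl in place of hydrogen on an aromatic carbon. Among the compounds with values here, the one step available, a 1.1-fold higher number from compound 1 to compound 2 (0.03 log units; within the scatter), is the same kind of change placed on another carbon of the core, and it stayed within the scatter. On that basis the expected step is a 1.3-fold higher number from compound 1 to compound 3 (0.10 log units; within the scatter), nothing beyond the usual spread. Compound 3 is therefore estimated at 1.3 nM, with a likely range from 0.5 nM to 3.5 nM.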

Compound 3, inhibition constant: 0.26 nM
Estimate against measurement, compound 3: 5.0-fold (0.70 log units) above; the whole stated range lies above it.
By their numbers in this assay, from the lowest: compound 3; then compounds 1 and 2 (each within the scatter of the next).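

In this assay, a methyl on another carbon of the core gave a 1.1-fold higher number from compound 1 to compound 2 (0.03 log units; within the scatter) and so no readable change, while the same swap on the carbon ortho to a fused ring and meta to the carboxymethoxy group gave a 4.0-fold lower number from compound 1 to compound 3 (0.60 log units; beyond the scatter) and a real gain in binding. Across these compounds, then, the effect of adding a methyl depends on which carbon of the core carries it, and this position responds to a single added carbon. Nothing shown here gives a reason for the difference between the two carbons.

From the compounds shown here alone, whether the gain belongs to methyl alone remains open, since only hydrogen and methyl have been compared at this carbon. An ethyl, a chlorine or a methoxy group there could show whether the number falls further or returns towards that of compound 1.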